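Two Extra Carbons at the Chain End of Compound 2

The source may hold more compounds than are shown below. What is called first, only, known or untested is meant among the compounds shown, and "the series" means these compounds.

Compound 2 `N/C(S)=N/CCCCn1nc(-c2ccccc2)ccc1=O` gives 72% in a functional assay on the whole organism with Rattus norvegicus as the target, at a dose of 100 mg/kg (a higher number here means more inhibition at the dose given (going by the name of the read-out), a lower number less inhibition), the highest of the two numbers measured; its nearest neighbour is compound 1 `CC/N=C(\S)NCCCCCCn1nc(-c2ccccc2)ccc1=O`, which gives -5.6%. Among the measured compounds shown here, the one step measured so far, a number 77.6 percentage points higher from compound 1 to compound 2 (beyond the scatter), came with a smaller group replacing a larger one on the same chain carbon, so a change in the opposite direction, toward more atoms at that end, is the nearest guide for compound 3 `C/N=C(\S)N(C)CCCCn1nc(-c2ccccc2)ccc1=O`. Compound 3 differs from compound 2 by a group of 6 heavy atoms (3 carbon, 2 nitrogen, 1 sulfur; no ring) in place of a group of 4 heavy atoms (1 carbon, 2 nitrogen, 1 sulfur; no ring), on a saturated chain carbon, four bonds along the chain from an aromatic nitrogen, and the added carbons here are few compared with the step between compound 1 and compound 2. The step expected in this assay is a number 42 percentage points lower from compound 2 to compound 3 (beyond the scatter), a fall beyond the scatter but not to the level of compound 1. Compound 3 is therefore estimated at 30%, with a likely range from -10% to 65%.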

Compound 3, a percentage reported as inhibition, in the whole organism at one dose (the size of the read-out at that dose, not a potency): 17.5%
Compound 3: middle estimate off by 12.5 percentage points, on the high side; low and high end bracket the measured number.
By their numbers in this assay, from the lowest: compound 1; then compound 3; then compound 2.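

In this assay, adding only a little to the group at this position already costs most of the effect, a number 54.5 percentage points lower from compound 2 to compound 3 (beyond the scatter), so even a small change at the chain end matters here. The third compound also gives a middle point, a number 23.1 percentage points higher from compound 1 to compound 3 (beyond the scatter), and across these three compounds the number falls as the group grows from 4 to 6 to 8 heavy atoms, with none going against that order. No measurement is available that explains the fall.

The entering group differs in two ways, with more carbons and with 1 hydrogen-bond donor where the leaving group has 2, and these compounds leave open which of the two goes with the lower number. On these data alone, how an amine or a carboxylic acid at this position would behave in this assay also remains open.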